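Thiophene for thiazole on the amide carbonyl

The compounds below may be only part of what the source reports. "The series", "measured", "known", "first", "only" and "open" are said of these compounds alone.

Measured in a functional assay on HCT-116 cells (Homo sapiens) for inhibition, read by colorimetric assay and sulforhodamine B assay, with a stated time of 48 h; a higher number here means a weaker inhibitor of growth, a lower number a stronger inhibitor of growth:
compound 1 `CCCCCCCCCCCC[C@@H](O)[C@H]1CC[C@H]([C@H](O)CCCCCCCCCCNC(=O)c2cccs2)O1`: 1290 nM
compound 2 `CCCCCCCCCCCC[C@@H](O)[C@H]1CC[C@H]([C@H](O)CCCCCCCCCCNC(=O)c2cncs2)O1`: 12900 nM

Compound 2 holds the higher number of the pair, at 12900 nM. Compound 3 `CCCCCCCCCCCC[C@@H](O)[C@H]1CC[C@H]([C@H](O)CCCCCCCCCCNC(=O)c2ccsc2)O1` is unmeasured and carries thiophen-3-yl in place of 1,3-thiazol-5-yl on a carbonyl carbon. Among the compounds with values here, one measured step bears on this change: 1,3-thiazol-5-yl in place of thiophen-2-yl on a carbonyl carbon gave a 10-fold higher number from compound 1 to compound 2 (1.00 log units; beyond the scatter). Within the data shown here, a step of similar size in the opposite direction is therefore expected, although no measurement yet tests thiophen-3-yl itself. The expected change in this assay is a 7.2-fold lower number from compound 2 to compound 3 (0.86 log units; beyond the scatter). For compound 3 the estimated value is 1800 nM, with an expected range of 600 nM to 5500 nM.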

Compound 3, concentration for 50% growth inhibition: 1290 nM
For compound 3 the middle estimate is 1.4-fold (0.14 log units) above the measured one; measured number inside the range.
By their numbers in this assay, from the lowest: compounds 1 and 3 (each within the scatter of the next); then compound 2.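

In this assay thiophen-3-yl in place of 1,3-thiazol-5-yl on a carbonyl carbon gives a 10-fold lower number from compound 2 to compound 3 (1.00 log units; beyond the scatter), so the gap to the thiazole is not confined to thiophen-2-yl. Thiophen-3-yl in place of thiophen-2-yl gives no change at the digits printed from compound 1 to compound 3 (within the scatter), so this series does not separate the two thiophene attachments. Among the three compounds, only compound 2 stands apart.

No measurement here accounts for the gap between the thiophenes and the thiazole. Going by these compounds, whether a phenyl or pyridin-3-yl ring on the same carbonyl would fall with the thiophenes or with compound 2 remains open.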